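Sulfonylurea series: aryl sulfonyl change at compound 1

This account rests on a few compounds, and the source may have more. Where it says the series, first, only, none or still open, it means among the compounds named here.

Measured so far:
- Compound 1, `COc1ccc(S(=O)(=O)NC(=O)NC/C=C2\CCCc3cnn(Cc4ccc(Cl)cc4Cl)c32)cc1`, 29 nM
- Compound 2, `O=C(NC/C(F)=C1\CCCc2cnn(Cc3ccc(C(F)(F)F)cc3)c21)NS(=O)(=O)c1cc(Cl)c(Cl)s1`, 52 nM

Both compounds were read in a functional assay on CHO-K1 cells for antagonist activity at prostaglandin E2 receptor EP3 subtype (Homo sapiens), read by TR-FRET and cAMP accumulation, with a stated time of 30 min; a higher number here means a weaker inhibitor, a lower number a stronger inhibitor. Compound 1 gives the lowest of the two numbers, but compound 2 sits only a short way from it and the two values fall within the usual scatter of each other, so no order between compound 1 and compound 2 can be claimed. Compound 2 also differs from compound 1 in more than one place, so its value says nothing on its own about the sulfonyl aryl group.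

Compound 3, `O=C(NC/C=C1\CCCc2cnn(Cc3ccc(Cl)cc3Cl)c21)NS(=O)(=O)c1cccs1`, has not yet been measured in this assay . It differs from compound 1 in one place: thiophen-2-yl in place of 4-methoxyphenyl on a sulfonyl sulfur. Within the data shown here, no single-point step between measured compounds exists for this change, so its size is not known from the series. The expectation is a small step, at most around the edge of the scatter, more likely toward a weaker number than a stronger one. The estimated step from compound 1 to compound 3 is a 1.7-fold higher number from compound 1 to compound 3 (0.24 log units; within the scatter). For compound 3 the estimate in this assay is 50 nM, with a range from 15 nM to 170 nM.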

Compound 3, half-maximal inhibitory concentration: 28 nM
Estimate against measurement, compound 3: 1.8-fold (0.25 log units) above, within the range that was stated.
By their numbers in this assay, from the lowest: compounds 3, 1 and 2 (each within the scatter of the next).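

In this assay, among these compounds, the first single-change reading at this position is a 1.0-fold lower number from compound 1 to compound 3 (0.02 log units; within the scatter). On a sulfonyl sulfur, the 4-methoxyphenyl group with 8 heavy atoms and one six-membered aromatic ring of carbon only can therefore be replaced by the thiophen-2-yl group with 5 heavy atoms and one five-membered aromatic ring with 1 hetero atom, with no difference that can be read beyond the scatter, though this holds only for this pair on the core of compound 1. Nothing available explains why the two groups read alike.

Going by these compounds, whether the same holds for other groups on the sulfonyl sulfur remains open, for example a plain methyl, a benzyl, a pyridin-3-yl, or an unsubstituted phenyl that would separate the methoxy group from the aromatic ring itself. On these data alone, compound 2 differs from compound 1 and from compound 3 in more than one place, so steps to it cannot be read, and the separate contribution of its chlorinated thiophene on the sulfonyl sulfur stays unknown.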